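The source may hold more compounds than are shown below. What is called first, only, known or untested is meant among the compounds shown, and "the series" means these compounds.

Three members of the series, sharing one core and differing only in the aryl on the carbonyl carbon, have numbers in a functional assay, with a stated time of 30 min; a lower number here means a stronger inhibitor, a higher number a weaker inhibitor. Compound 1 `COc1ccc(C2CC(=NOC(=O)c3ccc(Br)cc3)CC(c3ccc(OC)cc3)N2C)cc1` gives 121000 nM; compound 2 `COc1ccc(C2CC(=NOC(=O)c3ccccc3OC(C)=O)CC(c3ccc(OC)cc3)N2C)cc1` gives 350000 nM; compound 3 `COc1ccc(C2CC(=NOC(=O)c3cc(O)cc(O)c3)CC(c3ccc(OC)cc3)N2C)cc1` gives 19000 nM. Compound 1 thus stands second highest of the three, with a 2.9-fold higher number from compound 1 to compound 2 (0.46 log units; beyond the scatter) and a 6.4-fold lower number from compound 1 to compound 3 (0.80 log units; beyond the scatter), while the widest gap among them is an 18-fold lower number from compound 2 to compound 3 (1.27 log units; beyond the scatter).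

Compound 4 `COc1ccc(C(=O)ON=C2CC(c3ccc(OC)cc3)N(C)C(c3ccc(OC)cc3)C2)cc1` is the next member and is still to be measured in this assay. Relative to compound 1 the change is methoxy in place of bromo on an aromatic carbon. Both measured steps from compound 1 also alter only the aryl on the carbonyl carbon, yet neither puts a methoxy there: one brings in a 2-acetoxyphenyl and raises the number modestly, the other a 3,5-dihydroxyphenyl and lowers it modestly. A methoxy entering for a bromo is a smaller alteration than either of these, and a step no larger than modest is expected, direction uncertain, with a slight lowering somewhat more likely given compound 3 at 19000 nM. The expected step is a 1.5-fold lower number from compound 1 to compound 4 (0.18 log units; within the scatter). Compound 4 is accordingly estimated at 80000 nM, within a range of 30000 nM to 250000 nM.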

Compound 4, half-maximal inhibitory concentration: 68000 nM
Compound 4: middle estimate off by 1.2-fold (0.07 log units), on the high side, and the stated range covers the measured number.
By their numbers in this assay, from the lowest: compound 3; then compounds 4 and 1 (each within the scatter of the next); then compound 2.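

In this assay, going by these compounds alone, methoxy in place of bromo, on an aromatic carbon para to a large group, gives a 1.8-fold lower number from compound 1 to compound 4 (0.25 log units; within the scatter), so this position accepts either group without a step that can be told apart from repeat scatter, something the earlier compounds, which changed the whole aryl, could not show. The 4-methoxyphenyl also places the other two aryl groups on opposite sides of this pair, with a 3.6-fold higher number from compound 3 to compound 4 (0.55 log units; beyond the scatter) and a 5.1-fold lower number from compound 2 to compound 4 (0.71 log units; beyond the scatter): both steps are beyond the scatter, so the 3,5-dihydroxyphenyl and 2-acetoxyphenyl groups separate from both 4-substituted compounds, while the two para groups do not separate from each other. No available evidence bears on the reason for any of these steps.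

Open, going by these compounds, is whether an amine, a carboxylic acid or a longer chain such as butoxy, para to the same large group, would stay as close to compound 1 as methoxy does. Also open, on these data alone, is whether a single hydroxy on that carbon, as in a 4-hydroxyphenyl, would move the number toward that of compound 3 at 19000 nM.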